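Swapping the Furan Ring for a Carboxyphenyl Group

This account rests on a few compounds, and the source may have more. Where it says the series, first, only, none or still open, it means among the compounds named here.

Compound 1 `Oc1cccc(-c2ccc3c(-c4ccoc4)c(O)ccc3c2)c1` and compound 2 `Oc1cccc(-c2ccc3c(-c4cccnc4)c(O)ccc3c2)c1` share one core and differ in a single ring. In an in vitro assay on Sf9 cells for binding affinity to 17-beta-hydroxysteroid dehydrogenase type 1 (Homo sapiens), read by scintillation counting, with a stated time of 10 min, tested at 100 nM (a lower number here means a weaker effect, a higher number a stronger effect of the compound at the concentration tested), compound 1 gives 83% and compound 2 gives 87%, a step of a number 4 percentage points higher from compound 1 to compound 2 (within the scatter). Compound 1 thus sits at the smaller of the two numbers, though the gap lies within the scatter. Compound 3 `O=C(O)c1cccc(-c2c(O)ccc3cc(-c4cccc(O)c4)ccc23)c1` arises from compound 1 through the change (3-carboxyphenyl in place of furan-3-yl on an aromatic carbon). Among the compounds with values here, no measured step involves a 3-carboxyphenyl group; the only measured step at this place, exchanging one aromatic ring for another, stayed within the scatter. The expected step is therefore a number 5 percentage points lower from compound 1 to compound 3 (within the scatter), with no clear direction. Compound 3 is estimated at 78%, between 55% and 92%.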

Compound 3, a percentage reported as inhibition, at one concentration (the size of the read-out at that concentration, not a potency): 45%
Beside the measured number, compound 3's estimate is 33 percentage points above it, outside the stated range (below it).
By their numbers in this assay, from the lowest: compound 3; then compounds 1 and 2 (each within the scatter of the next).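

The ring at this position cannot be exchanged freely: the earlier swap between two aromatic rings stayed within the scatter, but in this assay, 3-carboxyphenyl gives a number 38 percentage points lower from compound 1 to compound 3 (beyond the scatter) and a number 42 percentage points lower from compound 2 to compound 3 (beyond the scatter). Nothing available explains this drop.

The compounds shown leave open whether the drop follows the carboxylic acid itself or the six-membered carbon ring that carries it. A plain phenyl ring, or a phenyl ring bearing a methyl ester in place of the acid, would tell these two apart.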